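A few compounds are considered here, and "the series" means these few. Any claim that something is new, unique, unknown or untested is made for them only; others in the source may bear on it.

In a functional assay on SK-MEL-5 cells (Homo sapiens) for cytotoxicity (on this read-out higher numbers stand for an effect only at larger amounts of compound and lower numbers for an effect already at smaller amounts), compound 1 `COc1cc(/C=C/c2ccc(C(C)C)cc2)cc(OC)c1OC` gives 11.1 uM and its double-bond isomer, compound 2 `COc1cc(/C=C\c2ccc(C(C)C)cc2)cc(OC)c1OC`, gives 4.7 uM. That is a 2.4-fold lower number from compound 1 to compound 2 (0.37 log units; beyond the scatter), which goes with the fact that compounds 1 and 2 differ only in the configuration as drawn. Compound 3 `CCCOc1ccc(/C=C/c2cc(OC)c(OC)c(OC)c2)cc1` gives > 25 uM, which is a limit and not a number. Compound 2 therefore holds the lower of the two actual numbers.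

The next compound, compound 4 `COc1cc(/C=C\c2ccc(SC)cc2)cc(OC)c1OC`, keeps the configuration of compound 2 and carries methylsulfanyl in place of isopropyl on an aromatic carbon. The configuration step does not bear directly on this change, since compound 2 and compound 4 share that feature. The closest guide is the replacement of the same isopropyl group by propoxy, which gave an at least 2.2-fold higher number from compound 1 to compound 3 (0.35 log units; beyond the scatter). That step shows that the number responds to a change at this place, but it involves a different entering group and the other double-bond configuration. The direction is therefore only weakly supported, and a modest move towards a lower number is tentatively expected, with no real change also possible. The expected change is a 1.9-fold lower number from compound 2 to compound 4 (0.27 log units; within the scatter). In this assay, the estimate for compound 4 is 2.5 uM, with an expected range from 0.4 uM to 12 uM.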

Compound 4, concentration for half-maximal effect: 4 uM
Estimate against measurement, compound 4: 1.6-fold (0.20 log units) below, within the range that was stated.
By their numbers in this assay, from the lowest: compounds 4 and 2 (each within the scatter of the next); then compound 1. At a limit, above all of these: compound 3.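

In this assay, within the data shown here, the swap of isopropyl for methylsulfanyl on an aromatic carbon, para to a large group, stays within the scatter (a 1.2-fold lower number from compound 2 to compound 4 (0.07 log units; within the scatter)), so this is the first step at this place that links two actual numbers, and it shows no real change even though the entering group brings sulfur and a hydrogen-bond acceptor that isopropyl lacks. The earlier step at this place led to compound 3, which has the other double-bond configuration and whose value (> 25 uM) is a limit and not a number. Nothing among the measurements shown gives a reason for the result with methylsulfanyl.

The compounds shown leave open whether methylsulfanyl would behave the same way on the other double-bond configuration, and whether propoxy would keep its limit if carried on the configuration of compound 2. They also leave open how far this place accepts other kinds of group, such as an amine, a carboxylic acid or a longer chain.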